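This account rests on a few compounds, and the source may have more. Where it says the series, first, only, none or still open, it means among the compounds named here.

In an ADME assay on HEK-293T cells (Homo sapiens) for inhibition, read by CCK-8 assay, with a stated time of 48 h, tested at 20 uM (on this read-out lower numbers stand for less inhibition of growth and higher numbers for more inhibition of growth at the one concentration tested), compound 3 (`COc1ccc(S(=O)(=O)Oc2ccccc2/C=C(\C#N)C(=O)Nc2nnc(Cc3ccc(C)cc3)s2)cc1`) stands highest of the three numbers at 28%. Compound 1 (`COc1ccc(Cc2nnc(NC(=O)/C(C#N)=C/c3ccccc3OS(=O)(=O)c3ccc(F)cc3)s2)cc1`) gives 6% and compound 2 (`N#C/C(=C\c1ccccc1OS(=O)(=O)c1ccc(F)cc1)C(=O)Nc1nnc(Cc2ccccc2)s1`) gives 6%, both lower beyond the scatter. Compound 4 (`Cc1ccc(Cc2nnc(NC(=O)/C(C#N)=C/c3ccccc3OS(=O)(=O)c3ccc(F)cc3)s2)cc1`) follows from compound 3 by fluoro in place of methoxy on an aromatic carbon. For the measured compounds named here, the only measured single-place step, no change at the digits printed from compound 1 to compound 2 (within the scatter), lies elsewhere in the molecule and bears only indirectly. Compound 1 and compound 2 both carry the (4-fluorophenyl)sulfonyl group of compound 4, and their values are the closest guide. A fall is therefore expected in this assay, estimated as a number 18 percentage points lower from compound 3 to compound 4 (beyond the scatter). Compound 4 is expected at 10%, with an estimated range of 0% to 24%.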

Compound 4, percent growth inhibition at one concentration: 11%
For compound 4 the middle estimate is 1 percentage points below the measured one; the range from low to high includes it.
By their numbers in this assay, from the lowest: compounds 1, 2 and 4 (each within the scatter of the next); then compound 3.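

In this assay, for the compounds shown here, going from (4-methoxyphenyl)sulfonyl to (4-fluorophenyl)sulfonyl gives a number 17 percentage points lower from compound 3 to compound 4 (beyond the scatter), the first measured step at this position, so the group here affects growth inhibition in this pair. With fluoro held, the other substituted site shows no effect beyond the scatter: methyl against hydrogen gives a number 5 percentage points higher from compound 2 to compound 4 (within the scatter), and methyl against methoxy gives a number 5 percentage points higher from compound 1 to compound 4 (within the scatter). Nothing available explains the fall at the sulfonyl-bearing position. From the compounds shown here alone, how an amine or a longer alkoxy chain would read in place of the methoxy remains open, as does whether the step holds with hydrogen or methoxy in place of the methyl.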